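A few compounds are considered here, and "the series" means these few. Any claim that something is new, unique, unknown or untested is made for them only; others in the source may bear on it.

Measured so far:

compound 1, `CC(C)(C)c1ccnc(N)n1` — in a functional assay on the whole organism for inhibition, with Rattus norvegicus as the target, with stated times of 1 h and 3.5 h, at a dose of 100 mg/kg by the oral route (a higher number here means more inhibition at the dose given (going by the name of the read-out), a lower number less inhibition), compound 1 gives 32%
compound 2, `CNc1nccc(C(C)(C)C)n1` — in this assay compound 2 gives 34%

Among the measured compounds shown here, compound 2 stands alongside compound 1 in this assay, the one measured step being a number 2 percentage points higher from compound 1 to compound 2 (within the scatter). Compound 3, `CC(C)(C)c1ccnc(S)n1`, carries a different change: sulfanyl in place of methylamino on an aromatic carbon. For the measured compounds named here, the only measured step concerns a methyl on a nitrogen, not sulfanyl in place of methylamino, so no step here speaks directly to this change. With no guide beyond that, the step from compound 2 to compound 3 in this assay is expected to be a number 8 percentage points lower from compound 2 to compound 3 (within the scatter), a small lowering, though none beyond the scatter would also fit. Compound 3 is therefore estimated at 26%, within 8% to 44%.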

Compound 3, a percentage reported as inhibition, in the whole organism at one dose (the size of the read-out at that dose, not a potency): 22%
The estimate for compound 3 lay 4 percentage points above the measured number; the measured number falls inside the stated range.
By their numbers in this assay, from the lowest: compounds 3, 1 and 2 (each within the scatter of the next, the first and the last beyond it).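

Among the compounds shown here, on the aromatic carbon between two ring nitrogen atoms, sulfanyl in place of methylamino gives a number 12 percentage points lower from compound 2 to compound 3 (beyond the scatter) in this assay, the first step in this set to pass the scatter. Sulfanyl in place of amino gives a number 10 percentage points lower from compound 1 to compound 3 (within the scatter), so the change stands out only against methylamino. No available data explain this difference.

As far as these compounds go, what a methoxy group or a longer amine chain would give on this carbon remains open. So does whether replacing the tert-butyl group would alter the effect of these changes.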